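Replacing 4-(dimethylamino)phenyl with 2-chlorophenyl on the shared core

The source may report more compounds than this note shows. Statements on the series, on what has been measured and on what is new or still open speak of the compounds shown alone.

Compound 1 `COc1ccccc1C1CC(c2cc3ccccc3o2)=NN1C(=O)c1ccncc1`, compound 2 `CN(C)c1ccc(C2CC(c3cc4ccccc4o3)=NN2C(=O)c2ccncc2)cc1` and compound 3 `COc1ccc(C2CC(c3cc4ccccc4o3)=NN2C(=O)c2ccncc2)c(O)c1` share one core and have all been read in an ADME assay on Vero cells (Chlorocebus sabaeus) for cytotoxicity, read by MTT assay, with a stated time of 72 h; a lower number here means a stronger inhibitor, a higher number a weaker inhibitor. Compound 2 gives > 210000 nM as a limit. Compound 1 gives > 202000 nM as a limit too. Compound 3 gives > 190000 nM as a limit as well. Compound 2 therefore has no exact number, and neither do the other two.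

Compound 4 `O=C(c1ccncc1)N1N=C(c2cc3ccccc3o2)CC1c1ccccc1Cl` is the next to be read, and the change 2-chlorophenyl in place of 4-(dimethylamino)phenyl on a saturated ring carbon separates it from compound 2. The measured steps that bear on this change are a step that the two limits leave unreadable from compound 1 to compound 2 and a step that the two limits leave unreadable from compound 1 to compound 3 and also a step that the two limits leave unreadable from compound 2 to compound 3 in this assay. They offer no size to carry over, although all three compounds ended at a limit. Only a step within the usual scatter is expected, with no direction. The expected change is an at least 1.0-fold lower number from compound 2 to compound 4 (0.02 log units; that floor lies within the scatter) on this estimate. For compound 4 the estimate is 200000 nM with an expected range from 100000 nM to 260000 nM in this reading.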

Compound 4, half-maximal inhibitory concentration: > 210000 nM
Compound 4 gave a limit, no number; the forecaster's own chance of this, stated with the estimate: 75%; middle value at least 1.0-fold (0.02 log units) away from the limit.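

In this assay compound 4 gives > 210000 nM, a limit and not a number, so no step can be read between it and compound 1, compound 2 or compound 3, which also gave limits. The compounds shown leave open how these phenyl groups on the shared core compare in this assay, since none has an exact value.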